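Chloro on the trifluoromethylphenyl group of compound 3

The source may report more compounds than this note shows. Statements on the series, on what has been measured and on what is new or still open speak of the compounds shown alone.

Values in a functional assay on COLO 205 cells (Homo sapiens) for inhibition, read by sulforhodamine B assay, with a stated time of 48 h (on this read-out lower numbers stand for stronger inhibition of growth and higher numbers for weaker inhibition of growth), for the series:
Compound 1 `O=C(Nc1cccc(-n2cc(-c3ccncc3)c(-c3ccc(Cl)c(O)c3)n2)c1)Nc1cccc(C(F)(F)F)c1` gives 7900 nM
Compound 2 `COc1cc(-c2nn(-c3cccc(NC(=O)Nc4ccc(Cl)c(Cl)c4)c3)cc2-c2ccncc2)ccc1Cl` gives 937 nM
Compound 3 `COc1cc(-c2nn(-c3cccc(NC(=O)Nc4cccc(C(F)(F)F)c4)c3)cc2-c2ccncc2)ccc1Cl` gives 894 nM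

Compound 3 sits at the low end of these three numbers, a place it shares with compound 2, while compound 1 stands clear of both. The change to compound 4 `COc1cc(-c2nn(-c3cccc(NC(=O)Nc4ccc(Cl)c(C(F)(F)F)c4)c3)cc2-c2ccncc2)ccc1Cl` is chloro in place of hydrogen on an aromatic carbon, ortho to a trifluoromethyl group, which turns 3-(trifluoromethyl)phenyl into 4-chloro-3-(trifluoromethyl)phenyl (chloro in place of hydrogen on an aromatic carbon). Going by the values given here, no measured step adds this chloro alone. The closest evidence is a 1.0-fold lower number from compound 2 to compound 3 (0.02 log units; within the scatter) for an exchange of the aryl group on the same amide-type nitrogen. The larger 8.8-fold lower number from compound 1 to compound 3 (0.95 log units; beyond the scatter) concerns a methyl on an oxygen in another part of the molecule and says little about this group. No step beyond the scatter is therefore expected in this assay and the estimate is a 1.4-fold lower number from compound 3 to compound 4 (0.14 log units; within the scatter) at most a slight move to a lower number. Compound 4 is estimated at 650 nM with an expected range from 250 nM to 1500 nM on this read-out.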

Compound 4, concentration for 50% growth inhibition: 711 nM
For compound 4 the middle estimate is 1.1-fold (0.04 log units) below the measured one; measured number inside the range.
By their numbers in this assay, from the lowest: compounds 4, 3 and 2 (each within the scatter of the next); then compound 1.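

In this assay, going by these compounds alone, chloro in place of hydrogen on an aromatic carbon, ortho to a trifluoromethyl group, gives a 1.3-fold lower number from compound 3 to compound 4 (0.10 log units; within the scatter), the first direct reading of this addition on the aryl group of the amide-type nitrogen. Trifluoromethyl in place of chloro on an aromatic carbon gives a 1.3-fold lower number from compound 2 to compound 4 (0.12 log units; within the scatter), so 3-(trifluoromethyl)phenyl, 3,4-dichlorophenyl and 4-chloro-3-(trifluoromethyl)phenyl do not separate across compound 2, compound 3 and compound 4. No supporting measurement bears on this result.

The compounds shown leave open whether an amine or a carboxylic acid on this aryl group would move the number beyond the scatter. Also open, going by these compounds, is whether an 8.8-fold lower number from compound 1 to compound 3 (0.95 log units; beyond the scatter) would recur with 4-chloro-3-(trifluoromethyl)phenyl in place of 3-(trifluoromethyl)phenyl.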